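The compounds below may be only part of what the source reports. "The series", "measured", "known", "first", "only" and "open" are said of these compounds alone.

In a functional assay on SW872 cells (Homo sapiens) for cytotoxicity, read by fluorescence and resazurin assay, with a stated time of 72 h (on this read-out higher numbers stand for weaker inhibition and lower numbers for stronger inhibition), compound 2 `Nc1nc(Nc2ccc(S(N)(=O)=O)cc2)sc1C(=O)c1cccc(F)c1` gives 3100 nM, the lower of the two actual numbers measured among three compounds sharing one core. Compound 1 `Nc1nc(Nc2ccc(S(N)(=O)=O)cc2)sc1C(=O)c1ccccc1[N+](=O)[O-]` gives 6900 nM, and the exchange of 2-nitrophenyl for 3-fluorophenyl on a carbonyl carbon amounts to a 2.2-fold lower number from compound 1 to compound 2 (0.35 log units; beyond the scatter). Compound 3 `Nc1nc(Nc2ccc(S(N)(=O)=O)cc2)sc1C(=O)c1ccc(S(N)(=O)=O)cc1` gives no number, only a limit of the assay, > 10000 nM.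

The next compound to be tested is compound 4 `Nc1cccc(C(=O)c2sc(Nc3ccc(S(N)(=O)=O)cc3)nc2N)c1`, which differs from compound 2 in a single place: amino in place of fluoro on an aromatic carbon. The 3-fluorophenyl group of compound 2 thus becomes a 3-aminophenyl group in compound 4. Among the measured compounds shown here, no measured step makes this exchange. For the measured compounds named here, the closest guide is the one step measured on the same aryl group, a 2.2-fold lower number from compound 1 to compound 2 (0.35 log units; beyond the scatter), which is modest even though it alters that group more broadly. On that basis, no step beyond the scatter is expected in this assay, and no direction can be favoured with confidence. The expected change is a 1.3-fold higher number from compound 2 to compound 4 (0.11 log units; within the scatter). For compound 4 the estimated value is 4000 nM, with an expected range of 1300 nM to 10000 nM.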

Compound 4, half-maximal inhibitory concentration: > 10000 nM
Compound 4: only a limit was reported (the forecaster's own chance of this, stated with the estimate: 15%); at least 2.5-fold (0.39 log units) between middle value and limit.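

In this assay compound 4 gives > 10000 nM, which is a limit of the assay and not a number. Even so, the position on the aromatic carbon meta to a large group proves sensitive to this exchange, something the earlier compounds could not show, since they changed the aryl group more broadly: exchanging fluoro for amino alone gives an at least 3.2-fold higher number from compound 2 to compound 4 (0.50 log units; beyond the scatter), so the 3-fluorophenyl group of compound 2 cannot be replaced by 3-aminophenyl without a real weakening in this assay. Against the 2-nitrophenyl group the picture is less clear, for an at least 1.4-fold higher number from compound 1 to compound 4 (0.16 log units; that floor lies within the scatter) does not establish a difference between the two aryl groups.

From the compounds shown here alone, how far compound 4 really lies past its limit stays open, so the step from fluoro to amino has a floor but no measured size, and the same ceiling affects the reading of this series: the limit of > 10000 nM in this assay, at which 2 of the 4 values shown sit. Also open is whether this weakening is particular to the amino group or would also appear with a hydroxyl, a methoxy or a methylamino group at this place, and whether a chloro would stay close to compound 2.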